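Acetoxy to chloro exchange across two cores

The source may hold more compounds than are shown below. What is called first, only, known or untested is meant among the compounds shown, and "the series" means these compounds.

Measured compounds:
compound 1, `CC(=O)OCCc1c(C)nc(Cl)nc1Cl`: > 100000 nM
compound 2, `COc1nc(C)c(CCOC(C)=O)c(OC)n1`: 65000 nM
compound 3, `Cc1nc(Cl)nc(Cl)c1CCCl`: 8000 nM

All three were run in a functional assay on MCF7 cells (Homo sapiens) for antiproliferative activity, read by MTT assay, with a stated time of 24 h; a lower number here means a stronger inhibitor, a higher number a weaker inhibitor. The value of compound 1 is a limit of the assay, not a number. Compound 3 differs from compound 1 by chloro in place of acetoxy on a saturated chain carbon, two bonds along the chain from an aromatic carbon, and this change gave an at least 12-fold lower number from compound 1 to compound 3 (1.09 log units; beyond the scatter). That step rests on (the limit of > 100000 nM in this assay, at which 1 of the 3 values shown sits), so its true size is open at the upper end.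

Compound 2 sits on a different core; the difference between the two cores is not broken down here. Among the numbers given, compound 2 has the highest, with compound 3 nearest.

Compound 4, `COc1nc(C)c(CCCl)c(OC)n1`, differs from compound 2 by chloro in place of acetoxy on a saturated chain carbon, two bonds along the chain from an aromatic carbon, the same change as made from compound 1 to compound 3. Compound 4 is expected to show a step of about a 13-fold lower number from compound 2 to compound 4 (1.11 log units; beyond the scatter) in this assay, on the reasoning that compound 2 starts from a measured number of 65000 nM and the earlier step was an at least 12-fold lower number from compound 1 to compound 3 (1.09 log units; beyond the scatter). The estimate for compound 4 is 5000 nM, expected between 1500 nM and 20000 nM.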

Compound 4, half-maximal inhibitory concentration: > 100000 nM
Compound 4: no number, only a limit; the forecaster's own chance of this, stated with the estimate: 5%; at least 20-fold (1.30 log units) between middle value and limit.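

In this assay compound 4 gives > 100000 nM, a limit of the assay and not a number. The step reads an at least 1.5-fold higher number from compound 2 to compound 4 (0.18 log units; that floor lies within the scatter), so the drop seen with this change on the core of compound 1 does not reappear on the core of compound 2, and the two steps differ: the same change on two cores in this assay, an at least 12-fold lower number (1.09 log units; beyond the scatter) from compound 1 to compound 3 and an at least 1.5-fold higher number (0.18 log units; that floor lies within the scatter) from compound 2 to compound 4, at least 19-fold (1.28 log units) apart, beyond the scatter of two such steps This shows that, for these two pairs, the result of the change depends on the core; it does not give the true size of either step or a reason for the gap, since each step has one end on a limit: the limit of > 100000 nM in this assay, at which 2 of the 4 values shown sit.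

Still open, from the compounds shown here alone, is how far compound 1 and compound 4 lie past that limit, and so how wide the gap between the two steps really is. Also open, going by these compounds, is whether an amine or a bromo group on the same chain carbon, or a longer chain carrying the chloro, would give a measurable number on the core of compound 4.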